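The source may hold more compounds than are shown below. What is called first, only, known or untested is meant among the compounds shown, and "the series" means these compounds.

Measured compounds:
compound 1, `Oc1ccc(-c2cc(-c3ccc(F)cc3)cc(-c3cccc(O)c3)n2)cc1` — in a functional assay on T47D cells (Homo sapiens) for inhibition (on this read-out lower numbers stand for stronger inhibition and higher numbers for weaker inhibition), compound 1 gives 5000 nM
compound 2, `Oc1ccc(-c2cc(-c3ccc(OC(F)(F)F)cc3)cc(-c3ccccc3O)n2)cc1` — in this assay compound 2 gives > 50000 nM

The value recorded for compound 2 is a limit of the assay, not a number; compound 2 thus sits at the limit of > 50000 nM in this assay, at which 1 of the 2 values shown sits, and its true potency is only bounded. Going by the values given here, compound 1, which carries the 3-hydroxyphenyl group and the 4-fluorophenyl group on the shared core, is the one compound with a numerical reading.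

Compound 3, `Oc1ccc(-c2cc(-c3ccc(OC(F)(F)F)cc3)cc(-c3cccc(O)c3)n2)cc1`, has not been measured. It differs from compound 2 in one place: 3-hydroxyphenyl in place of 2-hydroxyphenyl on an aromatic carbon. The two compounds have the same atoms, joined differently, so only the hydroxyl placement on that ring changes.

Among the compounds with values here, no step between measured compounds is available to size this change. Compound 1 shows that a 3-hydroxyphenyl-bearing member of the series can give a numerical reading, whereas compound 2 does not, but the two also differ in the group on the other ring, so nothing firm follows. The expectation is a step from compound 2 to compound 3 of an at least 3.3-fold lower number from compound 2 to compound 3 (0.52 log units; beyond the scatter), toward stronger inhibition, with a real chance that compound 3 again reports only a limit. Compound 3 is estimated at 15000 nM, in a range from 4000 nM to 60000 nM.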

Compound 3, half-maximal inhibitory concentration: 18900 nM
Beside the measured number, compound 3's estimate is 1.3-fold (0.10 log units) below it; the range from low to high includes it.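

At this position, on an aromatic carbon next to the ring nitrogen, 3-hydroxyphenyl in place of 2-hydroxyphenyl turns a limit into a numerical reading in this assay, with an at least 2.6-fold lower number from compound 2 to compound 3 (0.42 log units; beyond the scatter), so the placement of the hydroxyl alone is enough to shift the result beyond the scatter. The size of that step is only bounded, since the value for compound 2 is a limit and not a number: the limit of > 50000 nM in this assay, at which 1 of the 3 values shown sits.

With 3-hydroxyphenyl held fixed, trifluoromethoxy in place of fluoro gives a 3.8-fold higher number from compound 1 to compound 3 (0.58 log units; beyond the scatter), toward weaker inhibition, which shows that the group on the other ring also moves the reading, something the first two compounds could not separate.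

From the compounds shown here alone, only two hydroxyl placements are compared here, so it remains open whether the hydroxyl itself is needed on this ring, a question that an unsubstituted phenyl, a methoxyphenyl or an aminophenyl at the same position would address. Also open, going by these compounds, is whether 2-hydroxyphenyl paired with 4-fluorophenyl would again sit at a limit, and how a carboxylic acid on this ring would read.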